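A few compounds are considered here, and "the series" means these few. Any claim that something is new, unique, unknown or untested is made for them only; others in the source may bear on it.

Measured compounds:
Compound 1, `O=C(/C=C/c1ccc(Oc2ncnc3ccc(Cl)cc23)cc1)/C=C/c1c(Cl)cccc1Cl`: 9300 nM
Compound 2, `O=C(/C=C/c1ccccc1Oc1ncnc2ccc(Cl)cc12)/C=C/c1c(Cl)cccc1Cl`: 7980 nM

In a functional assay on PC-3 cells (Homo sapiens) for inhibition, read by MTT assay, with a stated time of 72 h (on this read-out lower numbers stand for stronger inhibition and higher numbers for weaker inhibition), compound 1 gives 9300 nM and compound 2 gives 7980 nM; the two numbers lie within the usual scatter of each other, so neither can be set above the other. Compound 3, `O=C(/C=C/c1ccc(Oc2ncnc3ccc(Cl)cc23)cc1)/C=C/c1cc([N+](=O)[O-])ccc1Cl`, has not been measured. It differs from compound 1 in one place: 2-chloro-5-nitrophenyl in place of 2,6-dichlorophenyl on a double-bonded chain carbon bound to a double-bonded chain carbon. Among the measured compounds shown here, no measured pair shows the effect of this change, so the step from compound 1 to compound 3 is expected to be small, a 1.2-fold lower number from compound 1 to compound 3 (0.07 log units; within the scatter), without a clear direction beyond the scatter. Compound 3 is therefore estimated at 8000 nM, in a range from 3000 nM to 25000 nM.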

Compound 3, half-maximal inhibitory concentration: 3150 nM
Compound 3: middle estimate off by 2.5-fold (0.40 log units), on the high side; the range from low to high includes it.
By their numbers in this assay, from the lowest: compound 3; then compounds 2 and 1 (each within the scatter of the next).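

In this assay, 2-chloro-5-nitrophenyl in place of 2,6-dichlorophenyl gives a 3.0-fold lower number from compound 1 to compound 3 (0.47 log units; beyond the scatter), a modest step. Among the compounds shown here, this is the first sign that the group on a double-bonded chain carbon bound to a double-bonded chain carbon can shift this number, which compound 1 and compound 2 alone could not show. Nothing measured here accounts for the step.

From the compounds shown here alone, it remains open whether the nitro group or the change in chlorine count carries the step, and whether an amine or a carboxylic acid in place of the nitro group would do the same. The same change on the core of compound 2 is also unresolved.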